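Swapping (4-chlorophenyl)(methyl)amino for ethyl(phenyl)amino on a sulfonyl sulfur

This account rests on a few compounds, and the source may have more. Where it says the series, first, only, none or still open, it means among the compounds named here.

In a functional assay on MCF7 cells (Homo sapiens) for antiproliferative activity, read by MTT assay, with a stated time of 72 h (a lower number here means a stronger inhibitor, a higher number a weaker inhibitor), compound 1 (`CN(c1ccccc1)S(=O)(=O)C1CC2OC1C(c1ccc(NC(=O)CCCCCCC(=O)O)cc1)=C2c1ccc(O)cc1`) gives 63800 nM, compound 2 (`Cc1ccc(N(C)S(=O)(=O)C2CC3OC2C(c2ccc(NC(=O)CCCCCCC(=O)O)cc2)=C3c2ccc(O)cc2)cc1`) gives 23200 nM, and compound 3 (`CN(c1ccc(Cl)cc1)S(=O)(=O)C1CC2OC1C(c1ccc(NC(=O)CCCCCCC(=O)O)cc1)=C2c1ccc(O)cc1`) gives 13700 nM. Compound 3 thus shares the low end of this short range with compound 2. The gap between those two is small: a 1.7-fold lower number from compound 2 to compound 3 (0.23 log units; within the scatter).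

Compound 4 (`CCN(c1ccccc1)S(=O)(=O)C1CC2OC1C(c1ccc(NC(=O)CCCCCCC(=O)O)cc1)=C2c1ccc(O)cc1`) carries ethyl(phenyl)amino in place of (4-chlorophenyl)(methyl)amino on a sulfonyl sulfur. Two things change at once. The chloro is lost, which is the reverse of a measured change: a 4.7-fold lower number from compound 1 to compound 3 (0.67 log units; beyond the scatter). Methyl also becomes ethyl, and no step was measured for that. The nearest guide is a methyl placed on an aromatic carbon, a different place: a 2.8-fold lower number from compound 1 to compound 2 (0.44 log units; beyond the scatter). It offers only weak support for some gain from the added carbon. A modest move to a higher number is therefore expected: a 2.6-fold higher number from compound 3 to compound 4 (0.41 log units; beyond the scatter). Compound 4 is estimated at 35000 nM, with an expected range of 13000 nM to 90000 nM.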

Compound 4, half-maximal inhibitory concentration: 19100 nM
For compound 4 the middle estimate is 1.8-fold (0.26 log units) above the measured one, within the range that was stated.
By their numbers in this assay, from the lowest: compounds 3, 4 and 2 (each within the scatter of the next); then compound 1.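

In this assay, among the compounds shown here, compound 4 gives the first reading of a change on the sulfonamide nitrogen itself, methyl in place of hydrogen on a saturated chain carbon bound to a sulfonamide nitrogen, and that step lies beyond the scatter (a 3.3-fold lower number from compound 1 to compound 4 (0.52 log units; beyond the scatter)). The ethyl(phenyl)amino group cannot be told apart from the two groups that carry a substituent on the aromatic ring, since both steps lie within the scatter (a 1.4-fold higher number from compound 3 to compound 4 (0.14 log units; within the scatter); a 1.2-fold lower number from compound 2 to compound 4 (0.08 log units; within the scatter)). No measurement accompanying these compounds accounts for the size of these steps.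

The compounds shown leave open whether a longer chain on that nitrogen, such as propyl, would lower the number further. They also leave open whether ethyl and chloro together on one sulfonamide would give more than either alone.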